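Swapping nitro for methoxy on the lactam-side ring

The source may hold more compounds than are shown below. What is called first, only, known or untested is meant among the compounds shown, and "the series" means these compounds.

Of the compounds shown here, three sharing one core have been measured in a functional assay on SH-SY5Y cells (Homo sapiens) for cytotoxicity, read by MTT assay, with stated times of 8 h, 30 min and 12 h, tested at 0.5 uM; a lower number here means a weaker effect, a higher number a stronger effect of the compound at the concentration tested. Compound 1 `N=C(NCc1ccccc1)[C@@H]1CCC(=O)N1Cc1ccc([N+](=O)[O-])cc1` gives 24% in this assay. Compound 2 `N=C(NCc1ccc(O)cc1)[C@@H]1CCC(=O)N1Cc1ccc([N+](=O)[O-])cc1` gives 31.3%, and compound 3 `COc1ccc(CNC(=N)[C@@H]2CCC(=O)N2Cc2ccc([N+](=O)[O-])cc2)cc1` gives 25.4%. Compound 1 has the lowest of the three numbers, yet its nearest neighbour, compound 3, and its furthest, compound 2, both sit within the scatter of it: a number 1.4 percentage points higher from compound 1 to compound 3 (within the scatter) and a number 7.3 percentage points higher from compound 1 to compound 2 (within the scatter).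

Compound 4 `COc1ccc(CN2C(=O)CC[C@H]2C(=N)NCc2ccccc2)cc1` is not yet measured. It differs from compound 1 in one place: methoxy in place of nitro on an aromatic carbon. Among the measured compounds shown here, none of the measured steps touches the nitro group; all three, including a number 5.9 percentage points lower from compound 2 to compound 3 (within the scatter), concern the other aromatic ring and stayed within the scatter. For the measured compounds named here, the only change involving a methoxy group, from compound 1 to compound 3, was small. The account therefore expects no step beyond the scatter for compound 4, a number 1 percentage points higher from compound 1 to compound 4 (within the scatter). Compound 4 is estimated at 25% in this assay, with a range from 13% to 38%.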

Compound 4, a percentage reported as activity, at one concentration (the size of the read-out at that concentration, not a potency): 21%
Compound 4: middle estimate off by 4 percentage points, on the high side, and the stated range covers the measured number.
By their numbers in this assay, from the lowest: compounds 4, 1, 3 and 2 (each within the scatter of the next, the first and the last beyond it).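

Among the compounds shown here, until now no step had touched the ring carrying the nitro group. Here, in this assay, methoxy on an aromatic carbon para to a large group gives a number 3 percentage points lower from compound 1 to compound 4 (within the scatter) and so leaves the read-out at this concentration within the scatter of compound 1, although the entering group has fewer heavy atoms and hydrogen-bond acceptors than nitro. The nitro group is therefore not needed for a read-out of this size in this pair, and no evidence is available on why the two groups give such similar numbers.

As far as these compounds go, whether this position accepts groups of other kinds, such as an amine, a carboxylic acid or a longer chain, stays open. So does the effect of plain hydrogen in place of nitro, and of methoxy here combined with hydroxy or methoxy on the other aromatic ring.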